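The compounds below may be only part of what the source reports. "The series", "measured", "known", "first", "only" and "open" are said of these compounds alone.

Working notes on the series. Among the compounds with values here, compound 2 `Nc1nn(C(=O)Nc2ccc(Cc3ccccc3)cc2)c2ccc(Cl)cc12` holds the lowest of the two numbers so far in a functional assay on M14 cells (Homo sapiens) for antiproliferative activity, read by sulforhodamine B assay, with a stated time of 48 h (on this read-out higher numbers stand for weaker inhibition of growth and lower numbers for stronger inhibition of growth), where compound 2 gives 88.8 nM. Within the data shown here, the nearest comparator is compound 1 `Nc1nn(C(=O)Nc2ccc(Cc3ccccc3)cc2)c2ccccc12`, the parent without the chloro, which in this assay gives 772 nM; the gain on adding chloro, an 8.7-fold lower number from compound 1 to compound 2 (0.94 log units; beyond the scatter), is the only step so far, and it is modest but beyond the scatter.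

Compound 3 `Nc1ccc2c(c1)c(N)nn2C(=O)Nc1ccc(Cc2ccccc2)cc1` is compound 2 with amino in place of chloro on an aromatic carbon. Among the measured compounds shown here, no measured pair shows chloro giving way to amino, so the only step that bears on it is an 8.7-fold lower number from compound 1 to compound 2 (0.94 log units; beyond the scatter), which tells how much the chloro itself is worth at that position relative to hydrogen. With the chloro gone, part or all of that gain is expected to be lost, and whether the amino recovers anything is not known from these two compounds. The expectation for compound 3 is therefore a higher number, with the step of a 3.9-fold higher number from compound 2 to compound 3 (0.60 log units; beyond the scatter) sitting between no change and a return to the level of compound 1. Compound 3 is estimated at 350 nM in this assay, with a range of 90 nM to 1500 nM.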

Compound 3, concentration for 50% growth inhibition: 4590 nM
Compound 3: middle estimate off by 13-fold (1.12 log units), on the low side, outside the stated range (above it).
By their numbers in this assay, from the lowest: compound 2; then compound 1; then compound 3.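

In this assay this aromatic carbon proves to work in both directions, which the single gain on adding chloro could not show: amino in place of chloro gives a 52-fold higher number from compound 2 to compound 3 (1.71 log units; beyond the scatter), a large step that exceeds the modest gain of an 8.7-fold lower number from compound 1 to compound 2 (0.94 log units; beyond the scatter). Amino in place of hydrogen at the same carbon gives a 5.9-fold higher number from compound 1 to compound 3 (0.77 log units; beyond the scatter), so the result is more than the loss of the chloro, and among these three compounds the amino stands on the far side of the unsubstituted parent from the chloro. No measurement here gives a reason for the fall in growth inhibition on moving to amino, so the three numbers describe the order at this carbon and nothing about its cause.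

On these data alone, it remains open whether a bromo, fluoro or methoxy at this carbon would lie nearer compound 2 or nearer compound 3, and whether an acetamido or dimethylamino would keep the poor standing of the free amino. Also open, as far as these compounds go, is whether the same order of chloro, hydrogen and amino would hold with the benzyl on the urea-linked phenyl replaced by another group.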